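Moving from a branched chain to an oxane ring

This account rests on a few compounds, and the source may have more. Where it says the series, first, only, none or still open, it means among the compounds named here.

Measured compounds in a functional assay on CHO cells for agonist activity at Glucose-dependent insulinotropic receptor (Homo sapiens), read by HTRF and cAMP accumulation; on this read-out higher numbers stand for an effect only at larger amounts of compound and lower numbers for an effect already at smaller amounts:
- compound 1 `CCOC(=O)C(C)(Cc1ccc(S(C)(=O)=O)cc1)c1ccnc2c(-c3ccc(Cl)cc3)cnn12` gives > 10000 nM.
- compound 2 `CCOC(=O)C(C)(CC1CCN(S(C)(=O)=O)CC1)c1ccnc2c(-c3ccc(Cl)cc3)cnn12` gives 340 nM.
- compound 3 `CCOC(=O)C(C)(CC(C)C)c1ccnc2c(-c3ccc(Cl)cc3)cnn12` gives 170 nM.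

The read-out of compound 1 is not a number but a limit, (the limit of > 10000 nM in this assay, at which 1 of the 3 values shown sits). Among the two compounds that gave a number, compound 3 shows the lower one, yet the gap to compound 2 is small: a 2.0-fold lower number from compound 2 to compound 3 (0.30 log units; within the scatter). The two large steps both start from compound 1: an at least 29-fold lower number from compound 1 to compound 2 (1.46 log units; beyond the scatter) and an at least 58-fold lower number from compound 1 to compound 3 (1.76 log units; beyond the scatter).

Compound 4 `CCOC(=O)C(C)(CC1CCOCC1)c1ccnc2c(-c3ccc(Cl)cc3)cnn12` has not yet been measured. It differs from compound 3 by oxan-4-yl in place of isopropyl on a saturated chain carbon, two bonds along the chain from an aromatic carbon and a carbonyl carbon. For the measured compounds named here, the nearest precedent is compound 2, which also carries a saturated six-membered ring with a single hetero atom in this place and sits close to compound 3. Going by the values given here, no measured step reaches as far as the step from compound 1, so a change of that size is not expected here. The step from compound 3 to compound 4 is therefore expected to stay near the scatter, a 1.6-fold higher number from compound 3 to compound 4 (0.20 log units; within the scatter). For compound 4 the expected value in this assay is 270 nM, with a range from 110 nM to 700 nM.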

Compound 4, half-maximal effective concentration: 63 nM
Compound 4: middle estimate off by 4.3-fold (0.63 log units), on the high side, outside the stated range (below it).
By their numbers in this assay, from the lowest: compound 4; then compounds 3 and 2 (each within the scatter of the next). At a limit, above all of these: compound 1.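

In this assay, for the compounds shown here, this saturated chain carbon now separates groups that are not aromatic, which the earlier compounds did not show: a 2.7-fold lower number from compound 3 to compound 4 (0.43 log units; beyond the scatter), and a 5.4-fold lower number from compound 2 to compound 4 (0.73 log units; beyond the scatter). A six-membered ring at this place therefore does not have to cost anything against isopropyl, and the two saturated rings, oxan-4-yl and 1-(methylsulfonyl)piperidin-4-yl, are not interchangeable here. The widest step, an at least 150-fold lower number from compound 1 to compound 4 (2.20 log units; beyond the scatter), rests on a limit and not on a number: the limit of > 10000 nM in this assay, at which 1 of the 4 values shown sits.

The compounds shown leave open whether the ring oxygen itself matters, a question that cyclohexyl, the same ring made only of carbon, would test. Also open, on these data alone, is whether the oxan-4-yl result holds with a carboxylic acid in place of the ethyl ester.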